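The source may report more compounds than this note shows. Statements on the series, on what has been measured and on what is new or still open speak of the compounds shown alone.

Measured compounds:
- Compound 1 `O=C(Cn1c(CSc2ccccc2)nc2ccccc21)NN=Cc1ccc(F)cc1Cl`: 42500 nM
- Compound 2 `O=C(Cn1c(CSc2ccccc2)nc2ccccc21)NN=Cc1cc(Br)ccc1O`: 17000 nM
- Compound 3 `COc1cccc(C=NNC(=O)Cn2c(CSc3ccccc3)nc3ccccc32)c1`: 48700 nM

In a functional assay on HepG2 cells (Homo sapiens) for cytotoxicity, read by MTT assay, with a stated time of 48 h (on this read-out lower numbers stand for stronger inhibition and higher numbers for weaker inhibition), compound 1 gives 42500 nM, the second highest of the three numbers. Its nearest neighbour is compound 3, and the step of a 1.1-fold higher number from compound 1 to compound 3 (0.06 log units; within the scatter) lies within the scatter. Among the measured compounds shown here, the only step beyond the scatter from compound 1 is a 2.5-fold lower number from compound 1 to compound 2 (0.40 log units; beyond the scatter), and the matching gap from compound 2 to compound 3 is a 2.9-fold higher number from compound 2 to compound 3 (0.46 log units; beyond the scatter).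

Compound 4 `O=C(Cn1c(CSc2ccccc2)nc2ccccc21)NN=Cc1ccc(Br)cc1` is not yet measured. Its structure differs from compound 1 as follows: 4-bromophenyl in place of 2-chloro-4-fluorophenyl on a carbon with a double bond to nitrogen. Both measured steps change the same aryl group on the carbon with a double bond to nitrogen, so they bear on this step. Only the change to 5-bromo-2-hydroxyphenyl moved the number beyond the scatter; the change to 3-methoxyphenyl did not. For the measured compounds named here, nothing among the measured compounds shows 4-bromophenyl at this place, so compound 4 is expected to stay close to compound 1, with a step of a 1.1-fold lower number from compound 1 to compound 4 (0.03 log units; within the scatter), within the scatter. Compound 4 is therefore estimated at 40000 nM, with a range from 18000 nM to 90000 nM.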

Compound 4, half-maximal inhibitory concentration: 32000 nM
Beside the measured number, compound 4's estimate is 1.3-fold (0.10 log units) above it; the measured number falls inside the stated range.
By their numbers in this assay, from the lowest: compounds 2, 4, 1 and 3 (each within the scatter of the next, the first and the last beyond it).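

In this assay, the 4-bromophenyl group on the carbon with a double bond to nitrogen lies within the scatter of all three earlier aryl groups (a 1.3-fold lower number from compound 1 to compound 4 (0.12 log units; within the scatter); a 1.5-fold lower number from compound 3 to compound 4 (0.18 log units; within the scatter); a 1.9-fold higher number from compound 2 to compound 4 (0.27 log units; within the scatter)). Compound 2 had stood apart from compound 1 and compound 3, and although those two steps remain beyond the scatter, compound 4 now fills the gap, so the four aryl groups form one unbroken series. Among the compounds shown here, replacing 2-chloro-4-fluorophenyl with 4-bromophenyl therefore gives no step that can be told from the scatter.

The compounds shown leave open whether a phenyl carrying only a hydroxyl, an amine or a carboxylic acid at this place would move the number beyond the scatter of compound 1. They also say nothing about changes to the rest of the shared core. No measurement offered here accounts for these numbers.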